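Working notes: aryl exchange from compound 2 to compound 3

A few compounds are considered here, and "the series" means these few. Any claim that something is new, unique, unknown or untested is made for them only; others in the source may bear on it.

Going by the values given here, compound 2 `O=C(NC1CCN(Cc2cccc(Cl)c2)CC1)c1ccc2ccccc2c1` gives 54 nM in an assay on isolated protein for displacement of a labelled ligand from D(4) dopamine receptor (Homo sapiens) (on this read-out lower numbers stand for stronger inhibition and higher numbers for weaker inhibition), the lowest of the two numbers measured so far. Compound 1 `O=C(NC1CCN(Cc2cccc(Cl)c2)CC1)c1cccc2ccccc12` gives 116 nM in this assay, a higher number than compound 2 and beyond the usual scatter. Compound 3 `O=C(NC1CCN(Cc2ccc(C(F)(F)F)cc2)CC1)c1ccc2ccccc2c1` differs from compound 2 by 4-(trifluoromethyl)phenyl in place of 3-chlorophenyl on a saturated chain carbon bound to an amine nitrogen in a ring. Among the compounds with values here, no measured pair shows this exchange, so the size of the step in this assay is unknown; a change close to the scatter, in either direction, seems as likely as not. Compound 3 is expected to give about 80 nM, within 25 nM to 250 nM, an estimated step of a 1.5-fold higher number from compound 2 to compound 3 (0.17 log units; within the scatter).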

Compound 3, inhibition constant: 84 nM
Compound 3: middle estimate off by 1.1-fold (0.02 log units), on the low side; low and high end bracket the measured number.
By their numbers in this assay, from the lowest: compounds 2, 3 and 1 (each within the scatter of the next, the first and the last beyond it).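

In this assay, 4-(trifluoromethyl)phenyl in place of 3-chlorophenyl on a saturated chain carbon bound to an amine nitrogen in a ring gives a 1.6-fold higher number from compound 2 to compound 3 (0.19 log units; within the scatter). This place therefore accepts a change in the aryl group, with 10 heavy atoms entering for 7, without a step beyond the scatter. Nothing at hand accounts for this result.

Still open, on these data alone, is whether a cyclohexyl group or a longer chain at this place would keep the number within the scatter. Also open, as far as these compounds go, is whether the same exchange on the core of compound 1 would give a similar step.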